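Aryl in Place of Methyl on the Amide Nitrogen

The compounds below may be only part of what the source reports. "The series", "measured", "known", "first", "only" and "open" are said of these compounds alone.

Compound 1 `COc1ccc(-n2nc(C(N)=O)nc2-c2cc(OC)c(OC)c(OC)c2)cc1`: 106%
Compound 2 `CNC(=O)c1nc(-c2cc(OC)c(OC)c(OC)c2)n(-c2ccc(OC)cc2)n1`: 109%
Compound 3 `COc1ccc(-n2nc(C(=O)Nc3ccc(C)cc3)nc2-c2cc(OC)c(OC)c(OC)c2)cc1`: 88%

In a functional assay on the whole organism for inhibition, with Rattus norvegicus as the target, read by paw edema, with stated times of 30 min and 3 h, at a dose of 0.28 mmol/kg by the oral route (on this read-out higher numbers stand for more inhibition at the one dose given (going by the name of the read-out) and lower numbers for less inhibition), compound 2 gives the highest of the three numbers, though compound 1 is within the scatter of it (a number 3 percentage points higher from compound 1 to compound 2 (within the scatter)), while compound 3 lies furthest (a number 21 percentage points lower from compound 2 to compound 3 (beyond the scatter)). Compound 4 `COc1ccc(-n2nc(C(=O)Nc3ccc(O)cc3)nc2-c2cc(OC)c(OC)c(OC)c2)cc1` differs from compound 2 at one place: 4-hydroxyphenyl in place of methyl on an amide-type nitrogen. For the measured compounds named here, the steps that bear on this both put a ring on that nitrogen in place of a small group and both were modest and downward: a number 21 percentage points lower from compound 2 to compound 3 (beyond the scatter) and a number 18 percentage points lower from compound 1 to compound 3 (beyond the scatter). A step of similar size and direction is therefore expected for compound 4, a number 19 percentage points lower from compound 2 to compound 4 (beyond the scatter). Compound 4 is estimated at 90%, with a range from 70% to 108%.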

Compound 4, a percentage reported as inhibition, in the whole organism at one dose (the size of the read-out at that dose, not a potency): 74%
The estimate for compound 4 lay 16 percentage points above the measured number; the measured number falls inside the stated range.
By their numbers in this assay, from the lowest: compound 4; then compound 3; then compounds 1 and 2 (each within the scatter of the next).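

In this assay, the ring on the amide-type nitrogen costs more when it carries hydroxy than when it carries methyl, with two large drops (a number 35 percentage points lower from compound 2 to compound 4 (beyond the scatter); a number 32 percentage points lower from compound 1 to compound 4 (beyond the scatter)). The change on the aromatic carbon alone also counts (a number 14 percentage points lower from compound 3 to compound 4 (beyond the scatter)), so at this position the outcome depends on what the ring carries, not only on the ring being there. Nothing available accounts for these drops.

On these data alone, it stays open whether an amine or a carboxylic acid in place of hydroxy on that ring would behave the same way. As far as these compounds go, it also stays open whether a longer chain in place of methyl on the nitrogen would hold the level of compound 2.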